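Fluoro for methoxy on the urea-linked phenyl ring

The source may report more compounds than this note shows. Statements on the series, on what has been measured and on what is new or still open speak of the compounds shown alone.

Measured compounds:
compound 1 `COc1cc(NC(=O)Nc2cccc(F)c2)cc(OC)c1OC` gives 65600 nM in a functional assay on ONS-76 cells (Homo sapiens) for cytotoxicity, read by MTT assay, with a stated time of 72 h; a lower number here means a stronger inhibitor, a higher number a weaker inhibitor
compound 2 `COc1ccc(NC(=O)Nc2cc(OC)c(OC)c(OC)c2)cc1` gives 12900 nM in this assay

Two compounds share a core and differ only in the aryl group on the amide-type nitrogen. Among the measured compounds shown here, compound 2 stands lowest of the two numbers in this assay, its nearest neighbour being compound 1, and the single measured step, a 5.1-fold lower number from compound 1 to compound 2 (0.71 log units; beyond the scatter), is the only one that bears on the question at hand.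

Compound 3 `COc1cc(NC(=O)Nc2ccc(F)cc2)cc(OC)c1OC` has not yet been measured in this assay. It differs from compound 2 in one place: fluoro in place of methoxy on an aromatic carbon, sitting para to a large group on the ring. For the measured compounds named here, compound 1 shows that a fluoro-bearing ring can give a weaker result than a methoxy-bearing one, so the step from compound 2 to compound 3 is expected to move the number upward, though no measured pair shows this exact exchange and the size is uncertain. Compound 3 is therefore estimated at 35000 nM, within 12000 nM to 100000 nM, a step of a 2.7-fold higher number from compound 2 to compound 3 (0.43 log units; beyond the scatter) expected from compound 2.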

Compound 3, half-maximal inhibitory concentration: 63300 nM
For compound 3 the middle estimate is 1.8-fold (0.26 log units) below the measured one; the range from low to high includes it.
By their numbers in this assay, from the lowest: compound 2; then compounds 3 and 1 (each within the scatter of the next).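

In this assay, the exchange of methoxy for fluoro on the aromatic carbon para to a large group now has a direct measure, a 4.9-fold higher number from compound 2 to compound 3 (0.69 log units; beyond the scatter). The earlier pair could only suggest this exchange. That pair also changed where the fluoro sat. The second new comparison separates the place of the fluoro from its presence: going from 3-fluorophenyl to 4-fluorophenyl gives a 1.0-fold lower number from compound 1 to compound 3 (0.02 log units; within the scatter), so these two fluoro placements cannot be told apart in this cell assay, and the lower number of compound 2 goes with the 4-methoxyphenyl group rather than with substitution at that ring position as such. Nothing measured here accounts for the difference between methoxy and fluoro.

The compounds shown leave open whether methoxy would keep its advantage at the ring position that the fluoro holds in compound 1. They also leave open how other groups on the para carbon, such as an amine, a hydroxyl or a longer ethoxy chain, would compare with methoxy, and so whether the oxygen or the attached carbon matters more.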